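This account rests on a few compounds, and the source may have more. Where it says the series, first, only, none or still open, it means among the compounds named here.

In a functional assay on cells (Tumor Cell line, Homo sapiens) for cytotoxicity (a higher number here means a weaker inhibitor of growth, a lower number a stronger inhibitor of growth), compound 1 (`COc1ccc(-c2cc(O)c3cccnc3n2)cc1`) gives 38000 nM, and compound 2 (`COc1cccc(-c2cc(O)c3cc(C)cnc3n2)c1`) gives 95.5 nM. Compound 2 therefore holds the lower of the two numbers, by a gap beyond the scatter. These two compounds differ in more than one place, so their gap cannot be assigned to any single change. Compound 3 (`COc1cccc(-c2cc(O)c3cccnc3n2)c1`) differs from compound 2 in one place: hydrogen in place of methyl on an aromatic carbon. Among the measured compounds shown here, no measured pair isolates this change, so the expectation is tentative. Compound 3 shares structural features with both measured compounds, and its number is expected to fall within their span, closer to compound 2 at 95.5 nM. In this assay, a higher number beyond the scatter is expected, meaning weaker growth inhibition. The expected change is a 16-fold higher number from compound 2 to compound 3 (1.20 log units; beyond the scatter). For compound 3, the estimated value is 1500 nM, with an expected range of 250 nM to 10000 nM.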

Compound 3, concentration for 50% growth inhibition: 135 nM
Beside the measured number, compound 3's estimate is 11-fold (1.05 log units) above it; measured number outside the range, below it.
By their numbers in this assay, from the lowest: compounds 2 and 3 (each within the scatter of the next); then compound 1.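

Among the compounds shown here, the single change of methyl to hydrogen, on the aromatic carbon two atoms from the ring nitrogen, gives a 1.4-fold higher number from compound 2 to compound 3 (0.15 log units; within the scatter) in this assay. For the compounds shown here, this is the first pair to isolate this position, and it shows that the methyl is not required for the low number of compound 2, since compound 3 carries hydrogen there and stays within the scatter of it. Nothing measured on the compounds explains this result.

Going by these compounds, whether an ethyl chain, an amine or a carboxylic acid on this carbon would keep the number at this level remains open. Compound 1 gives 38000 nM and compound 3 gives 135 nM, and the compounds shown do not tell whether methyl and hydrogen would also lie within the scatter of each other on the core of compound 1.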